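The source may report more compounds than this note shows. Statements on the series, on what has been measured and on what is new or still open speak of the compounds shown alone.

In a functional assay on HCT-116 cells (Homo sapiens) for cytotoxicity, with a stated time of 3 days (on this read-out higher numbers stand for weaker inhibition and lower numbers for stronger inhibition), compound 2 `C#Cc1nc(C(=O)OCC)cs1` gives > 40000 nM, which is a limit of the assay and not a number. Compound 1 `C#CCNC(=O)c1csc(C#Cc2ccccc2)n1`, which also carries a phenyl, gives > 40000 nM, and this too is a limit. The data therefore offer no measured potency to start from, only (the limit of > 40000 nM in this assay, at which 2 of the 2 values shown sit). Compound 3 `CCOC(=O)c1csc(C#Cc2ccccc2)n1` differs from compound 2 by phenyl in place of hydrogen on a triple-bonded carbon, with phenyl in place of hydrogen on a triple-bonded carbon. Among the measured compounds shown here, no measured step shows what this change does. A small expected move toward stronger inhibition is an at least 1.6-fold lower number from compound 2 to compound 3 (0.20 log units; that floor lies within the scatter). For compound 3 the estimated value is 25000 nM, within an expected range of 6000 nM to 60000 nM.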

Compound 3, half-maximal inhibitory concentration: > 40000 nM
Compound 3: only a limit was reported (the forecaster's own chance of this, stated with the estimate: 60%); middle value at least 1.6-fold (0.20 log units) away from the limit.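

Among the compounds shown here, compound 3, like compound 1 and compound 2, gives only a limit and not a number, so no step to compound 3 can be read: the limit of > 40000 nM in this assay, at which 3 of the 3 values shown sit. The compounds shown leave open which change, if any, would give a measurable value in this assay on these cells.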